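Furan-2-yl in place of 2-chlorophenyl: growth inhibition outlook

This account rests on a few compounds, and the source may have more. Where it says the series, first, only, none or still open, it means among the compounds named here.

Compound 1 `CC1=CC[C@H](C(C)(C)NC(=S)N/N=C/c2ccc(O)cc2)CC1` in a functional assay on MCF7 cells (Homo sapiens) for inhibition, read by sulforhodamine B assay, with a stated time of 48 h (on this read-out higher numbers stand for weaker inhibition of growth and lower numbers for stronger inhibition of growth), reaches only a limit, > 100000 nM. For the measured compounds named here, compound 2 `CC1=CC[C@H](C(C)(C)NC(=S)N/N=C/c2ccccc2Cl)CC1` in this assay gives 98300 nM, the only number so far, the other entry being (the limit of > 100000 nM in this assay, at which 1 of the 2 values shown sits). Going by the values given here, the step of an at least 1.0-fold lower number from compound 1 to compound 2 (0.00 log units; that floor lies within the scatter) is the sole measured step, and it stays within the scatter.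

Compound 3 `CC1=CC[C@H](C(C)(C)NC(=S)N/N=C/c2ccco2)CC1` differs from compound 2 by furan-2-yl in place of 2-chlorophenyl on a carbon with a double bond to nitrogen. Among the compounds with values here, the one measured step, exchanging the aromatic group on that carbon, gave an at least 1.0-fold lower number from compound 1 to compound 2 (0.00 log units; that floor lies within the scatter); nothing measured here points to a step beyond the scatter in this assay for this second exchange. Compound 3 is therefore expected near the limit region, at 100000 nM with a range from 40000 nM to 300000 nM. This expectation corresponds to a step of a 1.0-fold higher number from compound 2 to compound 3 (0.01 log units; within the scatter) from compound 2 to compound 3, with a real chance that only a limit is reported.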

Compound 3, concentration for total growth inhibition: 53700 nM
The estimate for compound 3 lay 1.9-fold (0.27 log units) above the measured number; the range from low to high includes it.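

In this assay, a five-membered aromatic ring with 1 hetero atom can stand on a carbon with a double bond to nitrogen in place of 2-chlorophenyl, with a 1.8-fold lower number from compound 2 to compound 3 (0.26 log units; within the scatter) as the outcome. Going by these compounds, the exchange of 4-hydroxyphenyl for furan-2-yl gives an at least 1.8-fold lower number from compound 1 to compound 3 (0.27 log units; that floor lies within the scatter) as its step, so only a floor can be read from it, and the true size stays unknown. The entry for compound 1 is a limit, not a number: the limit of > 100000 nM in this assay, at which 1 of the 3 values shown sits.

Whether any group at this place can move the number beyond the scatter remains open, since every step shown so far stays within it. A phenyl carrying an amine or a carboxylic acid at this place, or a change elsewhere on the shared core, would test this.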